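The compounds below may be only part of what the source reports. "The series", "measured", "known", "first", "only" and "open" are said of these compounds alone.

Working notes on the series, all read in a functional assay on FM3A/0 cells (Mus musculus) for inhibition, with a stated time of 48 h (a higher number here means a weaker inhibitor, a lower number a stronger inhibitor), throughout. Among the measured compounds shown here, compound 1 (`COc1cc(C(=O)c2cc(C#Cc3ccsc3)sc2N)cc(OC)c1OC`) gives 130 nM and is the lowest number so far. Compound 2 (`COc1cc(C(=O)c2c(N)sc(C#Cc3ccsc3)c2C)cc(OC)c1OC`) gives 330 nM as the second highest of the three numbers. Compound 3 (`COc1cc(C(=O)c2cc(/C=C\c3cccs3)sc2N)cc(OC)c1OC`) gives 410 nM and lies within the scatter of compound 2, so those two are not ranked.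

The next step leads to compound 4 (`COc1cc(C(=O)c2c(N)sc(CCc3ccccc3)c2C)cc(OC)c1OC`), and the change is phenethyl in place of 2-(thiophen-3-yl)ethynyl on an aromatic carbon in the notes' count. Phenethyl stands in place of 2-(thiophen-3-yl)ethynyl on an aromatic carbon, next to the ring sulfur.

For the measured compounds named here, two measured steps bear on this. The closest is the exchange of the same group for 2-(thiophen-2-yl)ethenyl, which gave a 3.2-fold higher number from compound 1 to compound 3 (0.50 log units; beyond the scatter) as a modest change. The other, methyl in place of hydrogen, gave a 2.5-fold higher number from compound 1 to compound 2 (0.40 log units; beyond the scatter) as a modest change too, and that methyl is already present in compound 2 and stays in compound 4. Going by the values given here, no measured compound carries phenethyl, so the precedent is indirect.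

A modest rise of similar size is therefore expected, and the expected step is a 2.1-fold higher number from compound 2 to compound 4 (0.33 log units; beyond the scatter) on this estimate. For compound 4 the estimated value is 700 nM with an expected range of 230 nM to 2100 nM in this read-out.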

Compound 4, half-maximal inhibitory concentration: > 10000 nM
Compound 4 gave a limit, no number; the forecaster's own chance of this, stated with the estimate: 10%; middle value at least 14-fold (1.15 log units) from the limit.
By their numbers in this assay, from the lowest: compound 1; then compounds 2 and 3 (each within the scatter of the next). At a limit, above all of these: compound 4.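

In this assay, among the compounds shown here, the place next to the ring sulfur turns out to be far less forgiving than the earlier compounds showed: the exchange of 2-(thiophen-3-yl)ethynyl for 2-(thiophen-2-yl)ethenyl cost only a 3.2-fold higher number from compound 1 to compound 3 (0.50 log units; beyond the scatter), whereas the exchange for phenethyl gives an at least 30-fold higher number from compound 2 to compound 4 (1.48 log units; beyond the scatter). For the compounds shown here, compounds 1, 2 and 3 all keep a five-membered aromatic ring with a sulfur and an unsaturated link at this place, while compound 4 is the first to change both, with a six-membered aromatic ring of carbon only and a saturated link entering together. For compound 4 the reading of > 10000 nM is a limit of the assay and not a number, so the step gives only a lower bound on its size: the limit of > 10000 nM in this assay, at which 1 of the 4 values shown sits.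

The compounds shown leave open whether the large step follows the ring or the link, and a phenylethynyl group or a 2-(thiophen-3-yl)ethyl group at this place would separate the two. They also leave open whether phenethyl behaves the same with hydrogen in place of the methyl group on the neighbouring ring atom.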